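A quinolin-6-yl step from compound 3

A few compounds are considered here, and "the series" means these few. Any claim that something is new, unique, unknown or untested is made for them only; others in the source may bear on it.

Measured in a functional assay on DU-145 cells (Homo sapiens) for cytotoxicity, read by MTT assay, with a stated time of 48 h; a higher number here means a weaker inhibitor, a lower number a stronger inhibitor:
- compound 1 `COc1ccc(-c2nc3ccccn3c2C(=O)/C=C\Nc2ccc3[nH]ccc3c2)cc1` gives 11300 nM
- compound 2 `COc1ccc(-c2nc3ccccn3c2C(=O)/C=C\Nc2ccc3cc[nH]c3c2)cc1` gives 10700 nM
- compound 3 `O=C(/C=C\Nc1ccc2[nH]ccc2c1)c1c(-c2ccc(Cl)cc2)nc2ccccn12` gives 1290 nM

Compound 3 has the lowest number of the three, and its gaps to compound 1 and compound 2 both lie beyond the scatter. The next compound, compound 4 `O=C(/C=C\Nc1ccc2ncccc2c1)c1c(-c2ccc(Cl)cc2)nc2ccccn12`, carries quinolin-6-yl in place of 1H-indol-5-yl on an amine nitrogen. Going by the values given here, only one measured step touches that amine nitrogen. With 1H-indol-6-yl in place of 1H-indol-5-yl, the series shows a 1.1-fold lower number from compound 1 to compound 2 (0.02 log units; within the scatter), so that change left the number in this assay unmoved. The larger step, an 8.8-fold lower number from compound 1 to compound 3 (0.94 log units; beyond the scatter), comes from chloro in place of methoxy on an aromatic carbon, and compound 4 keeps the chloro of compound 3, so this step does not apply to the new change. Among the compounds with values here, no measured compound carries quinolin-6-yl, so the data cannot show what this exchange does, and the expectation remains loose. A small step is expected, slightly upward: a 1.4-fold higher number from compound 3 to compound 4 (0.14 log units; within the scatter). Compound 4 is estimated at 1800 nM, with an expected range from 550 nM to 6000 nM.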

Compound 4, half-maximal inhibitory concentration: 13600 nM
Beside the measured number, compound 4's estimate is 7.6-fold (0.88 log units) below it, and the stated range ends below it.
By their numbers in this assay, from the lowest: compound 3; then compounds 2, 1 and 4 (each within the scatter of the next).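

In this assay, going by these compounds alone, the amine nitrogen proved far less tolerant than the only earlier step there suggested: a 1.1-fold lower number from compound 1 to compound 2 (0.02 log units; within the scatter) had left the number unmoved, whereas an 11-fold higher number from compound 3 to compound 4 (1.02 log units; beyond the scatter) shows that this position can respond strongly to the aryl group it carries. The exchange therefore does more than move the attachment point around an indole, since it replaces a five-membered aromatic ring and its hydrogen-bond donor with a six-membered aromatic ring carrying a hydrogen-bond acceptor, and it adds one heavy atom, with the loss in compound 4 accompanying these differences taken together. Nothing measured here separates these differences or gives a reason for the loss.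

The compounds shown leave open which of these differences matters, and a naphthyl group or an indazolyl group on the same amine nitrogen would help to pull them apart. They also leave open whether quinolin-6-yl would have a similar effect alongside the methoxy group of compound 1, since the only quinoline shown carries chloro.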